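The source may hold more compounds than are shown below. What is called first, only, known or untested is meant among the compounds shown, and "the series" means these compounds.

Compound 1 `CCCC(=O)Nc1ncc(-c2ccc(OC)cc2)n1C`: > 100000 nM
Compound 2 `Cn1cc(-c2ccccc2)nc1NC(=O)c1ccc(F)cc1`: > 50000 nM

In a toxicity assay on THP-1 cells (Homo sapiens) for inhibition (on this read-out lower numbers stand for higher toxicity in this test and higher numbers for lower toxicity in this test), compound 1 gives > 100000 nM, which is a limit of the assay and not a number. Compound 2 gives > 50000 nM, likewise only a limit. Neither compound therefore has a measured value, and the two cannot be ranked. Compound 3 `COc1ccc(-c2cnc(NC(=O)c3ccno3)n2C)cc1` carries 1,2-oxazol-5-yl in place of propyl on a carbonyl carbon. Among the compounds with values here, no measured step shows what this change does in this assay, so none beyond the scatter is expected, in either direction. The expected step of an at least 1.2-fold lower number from compound 1 to compound 3 (0.09 log units; that floor lies within the scatter) is accordingly small. For compound 3 the estimated value is 80000 nM, with an expected range of 30000 nM to 150000 nM.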

Compound 3, half-maximal cytotoxic concentration: > 100000 nM
Compound 3 was reported as a limit (the forecaster's own chance of this, stated with the estimate: 85%); middle value at least 1.2-fold (0.09 log units) from the limit.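

Within the data shown here, compound 1 and compound 3 both sit only at a limit of this assay, so no step between them can be read. The compounds shown leave open whether 1,2-oxazol-5-yl in place of propyl changes toxicity at all.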